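The source may hold more compounds than are shown below. What is called first, only, known or untested is meant among the compounds shown, and "the series" means these compounds.

Three compounds have been measured in an assay on CHO cells for displacement of a labelled ligand from adenosine receptor A1 (Homo sapiens), read by scintillation counting, tested at 10 uM; on this read-out lower numbers stand for less inhibition and higher numbers for more inhibition at the one concentration tested (going by the name of the read-out):

Compound 1, `CC(C)(C)Cc1c(-c2ccc(F)cc2F)sc(N)c1C(=O)c1ccc(Cl)cc1`: in this assay compound 1 gives 1%.
Compound 2, `CC(C)(C)Cc1c(-c2c(F)cccc2F)sc(N)c1C(=O)c1ccc(Cl)cc1`: in this assay compound 2 gives 1%.
Compound 3, `Cc1ccccc1-c1sc(N)c(C(=O)c2ccc(Cl)cc2)c1CC(C)(C)C`: in this assay compound 3 gives 1%.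

Compound 3 stands level with compounds 1 and 2 on these numbers. The step of no change at the digits printed from compound 1 to compound 3 (within the scatter) and the step of no change at the digits printed from compound 2 to compound 3 (within the scatter) both lie within the scatter, as does the step of no change at the digits printed from compound 1 to compound 2 (within the scatter), so every exchange of the aryl group at this ring carbon seen so far has left the read-out where it was.

Compound 4, `CC(C)(C)Cc1c(-c2cccs2)sc(N)c1C(=O)c1ccc(Cl)cc1`, carries the change (thiophen-2-yl in place of 2-methylphenyl on an aromatic carbon). All three measured steps bear on it, since each swaps one group for another at the same ring carbon, and each gave no change beyond the scatter. None of them, though, brought in a five-membered ring with a hetero atom, so the evidence is indirect. Compound 4 is therefore expected to show no step beyond the scatter, a number 2 percentage points higher from compound 3 to compound 4 (within the scatter). For compound 4 the estimated read-out is 3%, within a range from -8% to 15%.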

Compound 4, a percentage reported as inhibition, at one concentration (the size of the read-out at that concentration, not a potency): 1%
The estimate for compound 4 lay 2 percentage points above the measured number; the measured number falls inside the stated range.
By their numbers in this assay, from the lowest: compounds 1, 2, 3 and 4 (each within the scatter of the next).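

In this assay, a five-membered aromatic ring with a ring sulfur now sits at this carbon, and the comparisons give no change at the digits printed from compound 3 to compound 4 (within the scatter), no change at the digits printed from compound 2 to compound 4 (within the scatter) and no change at the digits printed from compound 1 to compound 4 (within the scatter). The lack of response therefore extends beyond the six-membered aromatic rings of carbon only in compounds 1, 2 and 3 to thiophen-2-yl, a group with fewer heavy atoms and one hydrogen-bond acceptor. No measurement is available here that would explain this result.

The compounds shown leave open whether a carboxylic acid, a piperidine or a longer alkyl chain at this carbon would move the read-out. From the compounds shown here alone, the neopentyl, amino and (4-chlorophenyl)carbonyl groups are the same in all four compounds, so what replacing any of them would do also remains open.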